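Chain branching at the aryl ketone in the benzoic acid series

This account rests on a few compounds, and the source may have more. Where it says the series, first, only, none or still open, it means among the compounds named here.

Three compounds of this series have numbers in an assay on HEK293 cells for positive allosteric modulation of metabotropic glutamate receptor 3 (Rattus norvegicus), read by thallium flux, with a stated time of 2.5 min; a lower number here means a smaller maximal response, a higher number a larger maximal response. Compound 1 `COc1cc(C(=O)O)ccc1OCCCCOc1ccc(C(=O)C(C)C)c(O)c1C` gives 25.6% in this assay. Compound 2 `Cc1c(OCCCCOCOc2ccc(C(=O)O)cc2)ccc(C(=O)CC2CCCC2)c1O` gives 46.9% in this assay. Compound 3 `CCCC(=O)c1ccc(OCCCCOc2cc(C(=O)O)ccc2OC)c(C)c1O` gives 64.2% in this assay, the highest of the three; its nearest neighbour is compound 2, a gap beyond the scatter, and the furthest is compound 1, a gap also beyond the scatter. Among the compounds with values here, no pair of these measured compounds differs in one place only, so no single step has been read off within the set.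

Compound 4 `COc1ccc(C(=O)O)cc1OCCCCOc1ccc(C(=O)CC(C)C)c(O)c1C` has not yet been measured in this assay. It differs from compound 3 in one place: methyl in place of hydrogen on a saturated chain carbon bound to two saturated chain carbons

Within the data shown here, the measured compounds give no direct precedent for this change. Compound 1 and compound 2 carry other groups at the ketone and also differ from compound 3 elsewhere, so their lower values in this assay cannot be assigned to the ketone side chain alone. The expectation for compound 4 is therefore anchored on compound 3, with a modest downward step expected, a number 9.2 percentage points lower from compound 3 to compound 4 (within the scatter), of a size that may still lie within the scatter. The estimated maximal response of compound 4 in this assay is 55%, with a range from 30% to 80%.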

Compound 4, largest response reached (reported as percent of maximum), in percent of the reference or control that the assay uses: 100%
For compound 4 the middle estimate is 45 percentage points below the measured one, outside the stated range (above it).
By their numbers in this assay, from the lowest: compound 1; then compound 2; then compound 3; then compound 4.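

In this assay, within the data shown here, the change from propylcarbonyl to isobutylcarbonyl, methyl in place of hydrogen on a saturated chain carbon bound to two saturated chain carbons, gives a number 35.8 percentage points higher from compound 3 to compound 4 (beyond the scatter) and is the first step that can be read at a single place. It shows that this carbon of the ketone side chain accepts a branch and that one added methyl can move the maximal response well beyond the scatter, with compound 4 reaching 100% on the otherwise unchanged core of compound 3. Compound 1 and compound 2 differ from these two in more than one place, so no steps involving them can be read, and no measured data offer an explanation for the rise.

Still open, going by these compounds, is whether the gain is specific to the isobutylcarbonyl group or persists with a longer chain, a tert-butyl group or a cyclopropyl ring at the same place. Also open, on these data alone, is whether it survives replacement of the carboxylic acid by a tetrazole, and whether potency follows the maximal response.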